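The source may report more compounds than this note shows. Statements on the series, on what has been measured and on what is new or still open speak of the compounds shown alone.

In an ADME assay on LLC-MK2 cells (Macaca mulatta) for cytotoxicity, read by spectrophotometry and crystal violet staining, with a stated time of 4 days (on this read-out higher numbers stand for lower toxicity in this test and lower numbers for higher toxicity in this test), compound 1 (`CC(C)n1ncc2c(C(=O)N3CCc4cccnc43)cc(-c3cccs3)nc21`) gives 50000 nM and compound 2 (`CC(C)n1ncc2c(C(=O)Nc3ccccc3F)cc(-c3cccnc3)nc21`) gives 50000 nM while compound 3 (`CC(C)n1ncc2c(C(=O)Nc3ccccc3F)cc(-c3cccs3)nc21`) gives 50000 nM and so stands level with both. Compound 4 (`CC(C)n1ncc2c(C(=O)Nc3cc(S(N)(=O)=O)ccc3F)cc(-c3cccs3)nc21`) differs from compound 3 by sulfamoyl in place of hydrogen on an aromatic carbon meta to a large group and para to a fluoro group.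

For the measured compounds named here, two measured steps bear on this only indirectly, as neither involves a sulfamoyl group: exchange of the group on the carbonyl carbon (no change at the digits printed from compound 1 to compound 3 (within the scatter)) and thiophen-2-yl in place of pyridin-3-yl (no change at the digits printed from compound 2 to compound 3 (within the scatter)). Both lie within the scatter. Going by the values given here, with no measured precedent for the new group, some uncertainty remains, but no movement in this assay is expected on this evidence. No step beyond the scatter is estimated (no change at the digits printed from compound 3 to compound 4 (within the scatter)) for this change. Compound 4 is estimated at 50000 nM with an expected range from 25000 nM to 70000 nM on this read-out.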

Compound 4, half-maximal cytotoxic concentration: 25000 nM
Compound 4: middle estimate off by 2.0-fold (0.30 log units), on the high side; low and high end bracket the measured number.
By their numbers in this assay, from the lowest: compounds 4, 1, 2 and 3 (each within the scatter of the next).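

Sulfamoyl in place of hydrogen, on the aromatic carbon meta to a large group and para to a fluoro group, gives a 2.0-fold lower number from compound 3 to compound 4 (0.30 log units; within the scatter) in this assay. For the compounds shown here, this position therefore takes a group of 4 heavy atoms with no step beyond the scatter on this read-out, whereas the earlier steps covered only the whole group on the carbonyl carbon and the exchange of pyridin-3-yl for thiophen-2-yl. No measured evidence bears on this result.

As far as these compounds go, whether an amine or a carboxylic acid at this same position would give a step beyond the scatter remains open. Also open, from the compounds shown here alone, is whether sulfamoyl would read the same with pyridin-3-yl in place of thiophen-2-yl on the shared core.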